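Halogen to Methyl on the Outer Amide Aryl

A few compounds are considered here, and "the series" means these few. Any claim that something is new, unique, unknown or untested is made for them only; others in the source may bear on it.

Three measured compounds share one core and differ only in the aryl group on an amide-type nitrogen. In a functional assay on A549 cells (Homo sapiens) for inhibition, read by CCK-8 assay, with a stated time of 72 h, tested at 10 uM (a higher number here means more inhibition of growth at the concentration tested, a lower number less inhibition of growth), compound 1 `CN(C)C(=O)c1cc2cnc(Nc3ccc(NC(=O)C4(C(=O)Nc5ccc(Br)cc5)CC4)cc3)nc2n1C1CCCC1` gives 90.3%, compound 2 `CN(C)C(=O)c1cc2cnc(Nc3ccc(NC(=O)C4(C(=O)Nc5cccc(Cl)c5)CC4)cc3)nc2n1C1CCCC1` gives 90.7%, and compound 3 `CN(C)C(=O)c1cc2cnc(Nc3ccc(NC(=O)C4(C(=O)Nc5cccc(Br)c5)CC4)cc3)nc2n1C1CCCC1` gives 92.2%. Compound 3 holds the highest of the three numbers, yet the steps of a number 0.4 percentage points higher from compound 1 to compound 2 (within the scatter), a number 1.9 percentage points higher from compound 1 to compound 3 (within the scatter) and a number 1.5 percentage points higher from compound 2 to compound 3 (within the scatter) all lie within the scatter, so the three are effectively alike. Compound 4 `Cc1ccc(NC(=O)C2(C(=O)Nc3ccc(Nc4ncc5cc(C(=O)N(C)C)n(C6CCCC6)c5n4)cc3)CC2)cc1` differs from compound 3 by 4-methylphenyl in place of 3-bromophenyl on an amide-type nitrogen. Among the compounds with values here, no measured step exchanges a halogen for a methyl, but moving or swapping halogens changed almost nothing, so compound 4 is expected to show a step of a number 3.2 percentage points lower from compound 3 to compound 4 (within the scatter) that stays within the scatter. Compound 4 is therefore estimated at 89%, ranging from 78% to 96%.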

Compound 4, percent growth inhibition at one concentration: 90.6%
Estimate against measurement, compound 4: 1.6 percentage points below; low and high end bracket the measured number.
By their numbers in this assay, from the lowest: compounds 1, 4, 2 and 3 (each within the scatter of the next).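

With methyl in place of halogen on the outer aryl, the compounds stay alike in this assay: the steps of a number 1.6 percentage points lower from compound 3 to compound 4 (within the scatter) and a number 0.1 percentage points lower from compound 2 to compound 4 (within the scatter) and a number 0.3 percentage points higher from compound 1 to compound 4 (within the scatter) all lie within the scatter. This position on the amide-type nitrogen therefore accepts the all-carbon 4-methylphenyl as well as the halogen-bearing phenyl groups, so a halogen is not required here for this read-out. Nothing available explains this sameness.

Still open, from the compounds shown here alone, is whether an amine, a carboxylic acid or a longer chain on this aryl would keep the number. A single tested concentration also cannot show whether these four compounds would separate at lower concentrations.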